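The source may hold more compounds than are shown below. What is called first, only, known or untested is meant among the compounds shown, and "the series" means these compounds.

Two compounds have been tested in a functional assay on MCF7 cells (Homo sapiens) for cytotoxicity, read by MTT assay, with a stated time of 72 h; a higher number here means a weaker inhibitor, a lower number a stronger inhibitor:

compound 1 `NS(=O)(=O)c1cc(-c2nnc(CN3CCC(Cc4ccccc4)CC3)o2)c(Cl)cc1SCc1ccccc1`, which gives 170000 nM
compound 2 `CCOC(=O)c1cn(Cc2nnc(-c3cc(S(N)(=O)=O)c(SCc4ccccc4)cc3Cl)o2)nn1`, which gives 150000 nM

Among the measured compounds shown here, compound 2 shows the lowest of these two numbers, but its only neighbour, compound 1, sits within the usual scatter of it, so the two values cannot be ranked against each other; both simply describe weak activity. Both share the same core, and differ only in the group carried on the five-membered ring that holds two nitrogen and one oxygen.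

The piece now follows the step from compound 2 to compound 3 `NS(=O)(=O)c1cc(-c2nnc(/C=C/c3ccc(Cl)cc3)o2)c(Cl)cc1SCc1ccccc1`. The change is 2-(4-chlorophenyl)ethenyl in place of (4-(ethoxycarbonyl)-1H-1,2,3-triazol-1-yl)methyl on an aromatic carbon. For the measured compounds named here, no step between two measured compounds touches this position, so there is no measured guide for it. With the two measured values lying so close to each other, the expectation is a step of modest size, in either direction, most likely not beyond the scatter. The step from compound 2 to compound 3 is thus expected to be a 1.3-fold lower number from compound 2 to compound 3 (0.10 log units; within the scatter). Compound 3 is expected to give about 120000 nM in this assay, within a range from 40000 nM to 400000 nM.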

Compound 3, half-maximal inhibitory concentration: 11000 nM
Compound 3: middle estimate off by 11-fold (1.04 log units), on the high side; the whole stated range lies above it.
By their numbers in this assay, from the lowest: compound 3; then compounds 2 and 1 (each within the scatter of the next).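

In this assay the group on the aromatic carbon of the five-membered aromatic ring with 2 nitrogen and 1 oxygen proves able to move the number a long way: putting 2-(4-chlorophenyl)ethenyl in place of (4-(ethoxycarbonyl)-1H-1,2,3-triazol-1-yl)methyl gives a 14-fold lower number from compound 2 to compound 3 (1.13 log units; beyond the scatter) and is a large step, something the close values of compound 1 and compound 2 gave no hint of. The change swaps a five-membered aromatic ring with 3 hetero atoms and 5 hydrogen-bond acceptors for a six-membered aromatic ring of carbon only with 0 hydrogen-bond acceptors, and this single pair cannot show which of these differences carries the step. No measurement is available that explains the drop in the number.

As far as these compounds go, it remains open whether the step needs the chlorine, the ethenyl link or both, a question that a fluorine or a methoxy group in place of that chlorine, or a saturated ethyl link in place of the ethenyl, could help to settle. Also open, from the compounds shown here alone, is whether an amine or a carboxylic acid on the phenyl ring would keep the number this low.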